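The source may report more compounds than this note shows. Statements on the series, on what has been measured and on what is new or still open speak of the compounds shown alone.

Measured so far in a functional assay on MCF7 cells (Homo sapiens) for inhibition, read by MTT assay, with a stated time of 48 h; on this read-out higher numbers stand for weaker inhibition and lower numbers for stronger inhibition:
compound 1 `CCNC(=O)/C=C/c1c(/C=C/c2ccc(OC)cc2)cc(OC)cc1OC` gives 7060 nM
compound 2 `CCCCCCCCNC(=O)/C=C/c1c(/C=C/c2ccc(OC)cc2)cc(OC)cc1OC` gives 4280 nM
compound 3 `CCCCN(CCCC)C(=O)/C=C/c1c(/C=C/c2ccc(OC)cc2)cc(OC)cc1OC` gives 3990 nM

Compound 1 shows the highest of the three numbers, but both other compounds lie within the scatter of it: a 1.6-fold lower number from compound 1 to compound 2 (0.22 log units; within the scatter) and a 1.8-fold lower number from compound 1 to compound 3 (0.25 log units; within the scatter). Compound 2 and compound 3 likewise sit close together, a 1.1-fold lower number from compound 2 to compound 3 (0.03 log units; within the scatter). Across these three, changing the substitution on the amide nitrogen has not moved the read-out beyond the scatter.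

Compound 4 `COc1ccc(/C=C/c2cc(OC)cc(OC)c2/C=C/C(=O)N(CC(C)C)CC(C)C)cc1` is not yet measured. Relative to compound 1 it carries diisobutylamino in place of ethylamino on a carbonyl carbon. For the measured compounds named here, the closest precedent is the step to compound 3, a 1.8-fold lower number from compound 1 to compound 3 (0.25 log units; within the scatter), dibutylamino in place of ethylamino on a carbonyl carbon; the step to compound 2, a 1.6-fold lower number from compound 1 to compound 2 (0.22 log units; within the scatter), hexyl in place of hydrogen on a saturated chain carbon two bonds along the chain from an amide-type nitrogen, was of the same small size. Neither cleared the scatter, so for compound 4 no step beyond the scatter is expected in this assay, at most a slight lowering of the number in line with those two. Compound 4 is therefore estimated at 4500 nM, between 2000 nM and 10000 nM, an expected step of a 1.6-fold lower number from compound 1 to compound 4 (0.20 log units; within the scatter).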

Compound 4, half-maximal inhibitory concentration: 2390 nM
Compound 4: the middle estimate sits 1.9-fold (0.27 log units) above what was measured; the measured number falls inside the stated range.
By their numbers in this assay, from the lowest: compounds 4, 3, 2 and 1 (each within the scatter of the next, the first and the last beyond it).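

In this assay, for the compounds shown here, the diisobutylamino group on the carbonyl carbon gives the first step at this position that lies beyond the scatter (a 3.0-fold lower number from compound 1 to compound 4 (0.47 log units; beyond the scatter)), where the earlier replacements of ethylamino stayed within it. That separation holds only against compound 1, since compound 4 cannot be told apart from the other two larger amides (a 1.7-fold lower number from compound 3 to compound 4 (0.22 log units; within the scatter); a 1.8-fold lower number from compound 2 to compound 4 (0.25 log units; within the scatter)), and both of those steps are within the scatter, so branched diisobutylamino shows no distinct advantage over dibutylamino or octylamino. Nothing available on this series explains why this replacement alone clears the scatter.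

The series as shown does not settle whether the separation from compound 1 tracks the branching, the overall size of the nitrogen substituents, or the loss of the amide hydrogen, as compound 2 keeps that hydrogen while compound 3 and compound 4 lack it, and all three remain within the scatter of one another. It also leaves open how the read-out would respond to a piperidine or morpholine ring in place of diisobutylamino, or to a chain on the amide nitrogen carrying a carboxylic acid.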